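This account rests on a few compounds, and the source may have more. Where it says the series, first, only, none or still open, it means among the compounds named here.

Three thiosemicarbazone-type compounds built on a pyridine-bearing amidrazone core were tested in a functional assay on A-431 cells (Homo sapiens) for cytotoxicity, read by MTT assay, with a stated time of 72 h, tested at 30 uM; a higher number here means more inhibition of growth at the concentration tested, a lower number less inhibition of growth. Compound 1 `N/C(=N\NC(=S)N1CCCCCC1)c1ccccn1` carries a seven-membered saturated ring on the thiocarbonyl nitrogen, and in this assay compound 1 gives 72.3%. Compound 2 `N/C(=N\NC(=S)N1CCSCC1)c1ccccn1` carries a six-membered ring with a sulfur in it instead; in this assay compound 2 gives 81.3%. The difference between the core of compound 1 and the core of compound 2 is not broken down here, and their two values lie within the scatter of each other. Compound 3 `N/C(=N\NC(=S)N1CCSCC1)c1ccc(F)cn1` is compound 2 with fluoro in place of hydrogen on an aromatic carbon. In this assay compound 3 gives 84.6%, which is a number 3.3 percentage points higher from compound 2 to compound 3 (within the scatter). Compound 3 does sit beyond the scatter above compound 1.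

Compound 4 `N/C(=N\NC(=S)N1CCCCCC1)c1ccc(F)cn1` has not yet been measured in this assay. It differs from compound 1 by fluoro in place of hydrogen on an aromatic carbon, the same change that separates compound 3 from compound 2. Because the step of a number 3.3 percentage points higher from compound 2 to compound 3 (within the scatter) was small, a similarly small step is expected from compound 1 to compound 4, estimated at a number 3.2 percentage points higher from compound 1 to compound 4 (within the scatter). On that basis compound 4 is expected to give about 75.5% in this assay, with the estimate spanning 62% to 87%.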

Compound 4, percent growth inhibition at one concentration: 81.3%
The estimate for compound 4 lay 5.8 percentage points below the measured number, and the stated range covers the measured number.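

In this assay, fluoro in place of hydrogen on an aromatic carbon, two atoms from the ring nitrogen and para to a large group, gives a number 9 percentage points higher from compound 1 to compound 4 (within the scatter). Set beside the same change on the other core, the two steps cannot be told apart: the same change on two cores in this assay, a number 3.3 percentage points higher (within the scatter) from compound 2 to compound 3 and a number 9 percentage points higher (within the scatter) from compound 1 to compound 4, 5.7 percentage points apart, within the scatter of two such steps. This shows that, across these two cores, the change behaves alike as far as this read-out can tell, but each step on its own lies within the scatter, so it does not show that fluoro raises growth inhibition on either core, and two cores are too few to establish a rule for the series.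

The compounds shown leave open whether a chloro, a methoxy or a nitrile in that same place would give a step that stands clear of the scatter, and whether any such group would behave alike on both cores. They also leave open how the fluoro step would look at other concentrations, since a reading at a single concentration gives percent growth inhibition and no full concentration-response curve for any of the four compounds.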